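Hydroxy in Place of Nitro on the Benzylamide of Compound 2

This account rests on a few compounds, and the source may have more. Where it says the series, first, only, none or still open, it means among the compounds named here.

Measured so far:
compound 1 `COc1ccc(COC(=O)[C@H](CSCC2CCCCC2)NC(=O)[C@@H]2CSCN2C(=O)OC(C)(C)C)cc1` — 390 nM
compound 2 `CC(C)(C)OC(=O)N1CSC[C@H]1C(=O)N[C@@H](CSCC1CCCCC1)C(=O)NCc1ccc([N+](=O)[O-])cc1` — 600 nM

Of the compounds shown here, two have been tested in an assay on IMR-32 cells for inhibition of Voltage-dependent N-type calcium channel subunit alpha-1B (Homo sapiens); on this read-out lower numbers stand for stronger inhibition and higher numbers for weaker inhibition. Compound 1 gives 390 nM, and compound 2 gives 600 nM. Within the data shown here, the only step between them, a 1.5-fold higher number from compound 1 to compound 2 (0.19 log units; within the scatter), replaces (4-nitrobenzyl)amino with (4-methoxybenzyl)oxy on a carbonyl carbon. Compound 2 therefore stands with the higher of the two numbers, but its gap to compound 1 lies within the scatter, so the two cannot be ranked.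

Compound 3 `CC(C)(C)OC(=O)N1CSC[C@H]1C(=O)N[C@@H](CSCC1CCCCC1)C(=O)NCc1ccc(O)cc1` has not been measured. It differs from compound 2 by hydroxy in place of nitro on an aromatic carbon, para to a large group. Among the measured compounds shown here, no measured step touches this position; the single step of a 1.5-fold higher number from compound 1 to compound 2 (0.19 log units; within the scatter) changes a different part of the molecule and stayed within the scatter. Nothing in the data points to a shift beyond the scatter in this assay, so the step is expected to be a 1.2-fold higher number from compound 2 to compound 3 (0.07 log units; within the scatter). Compound 3 is estimated at 700 nM, with a range from 250 nM to 2000 nM.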

Compound 3, half-maximal inhibitory concentration: 1800 nM
Compound 3: the middle estimate sits 2.6-fold (0.41 log units) below what was measured; low and high end bracket the measured number.
By their numbers in this assay, from the lowest: compounds 1 and 2 (each within the scatter of the next); then compound 3.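

In this assay, the aromatic carbon para to a large group proves sensitive to what it carries: hydroxy in place of nitro gives a 3.0-fold higher number from compound 2 to compound 3 (0.48 log units; beyond the scatter), the first step shown that lies beyond the scatter. (4-Hydroxybenzyl)amino in place of (4-methoxybenzyl)oxy on the carbonyl carbon gives a 4.6-fold higher number from compound 1 to compound 3 (0.66 log units; beyond the scatter), so the hydroxy compound stands apart from both earlier compounds, which themselves cannot be ranked. No measurement offered here explains the higher number.

As far as these compounds go, whether the higher number comes from losing nitro or from gaining hydroxy stays open, with only these two groups seen at this place. An amine, a methoxy group or a chlorine atom on the same aromatic carbon would help separate those two readings.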